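From 4-(trifluoromethoxy)phenyl to 3-(trifluoromethoxy)phenyl on a sulfonyl sulfur

The source may hold more compounds than are shown below. What is called first, only, known or untested is meant among the compounds shown, and "the series" means these compounds.

In a functional assay on DU-145 cells (Homo sapiens) for antiproliferative activity, read by propidium iodide staining, with a stated time of 96 h (a lower number here means a stronger inhibitor, a higher number a weaker inhibitor), compound 1 (`CC(O)(CS(=O)(=O)c1cccc(C(F)(F)F)c1)C(=O)Nc1cccc(S(F)(F)(F)(F)F)c1`) gives 37300 nM and compound 2 (`CC(O)(CS(=O)(=O)c1ccc(OC(F)(F)F)cc1)C(=O)Nc1cccc(S(F)(F)(F)(F)F)c1`) gives 35600 nM so the two stand level within the scatter. The next compound, compound 3 (`CC(O)(CS(=O)(=O)c1cccc(OC(F)(F)F)c1)C(=O)Nc1cccc(S(F)(F)(F)(F)F)c1`), has 3-(trifluoromethoxy)phenyl in place of 4-(trifluoromethoxy)phenyl on a sulfonyl sulfur. This change, 3-(trifluoromethoxy)phenyl in place of 4-(trifluoromethoxy)phenyl on a sulfonyl sulfur keeps the same atoms and joins them differently. For the measured compounds named here, the one measured step at this place is a 1.0-fold lower number from compound 1 to compound 2 (0.02 log units; within the scatter) and it replaced 3-(trifluoromethyl)phenyl with 4-(trifluoromethoxy)phenyl without leaving the scatter. Going by the values given here, that is thin evidence, since no measured pair shows the same group changing its position. On that step alone, the expected 1.0-fold higher number from compound 2 to compound 3 (0.00 log units; within the scatter) in this assay stays within the scatter, with neither direction favoured. Compound 3 is therefore estimated at 36000 nM (expected range 18000 nM to 70000 nM).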

Compound 3, half-maximal inhibitory concentration: 31500 nM
The estimate for compound 3 lay 1.1-fold (0.06 log units) above the measured number; the range from low to high includes it.
By their numbers in this assay, from the lowest: compounds 3, 2 and 1 (each within the scatter of the next).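

In this assay, for the compounds shown here, replacing 4-(trifluoromethoxy)phenyl with 3-(trifluoromethoxy)phenyl on the sulfonyl sulfur gives a 1.1-fold lower number from compound 2 to compound 3 (0.05 log units; within the scatter) and provides the first measured pair in which the same group changes position, showing no shift beyond the scatter for this move. Changing the group itself, with trifluoromethoxy in place of trifluoromethyl on an aromatic carbon, gives a 1.2-fold lower number from compound 1 to compound 3 (0.07 log units; within the scatter) and so also stays within the scatter. No measured evidence is available to explain why these changes leave the number in place.

The compounds shown leave open whether a phenyl ring carrying an amine or a carboxylic acid in place of trifluoromethoxy would stand apart from these three. They also leave open what a change elsewhere on the shared core would do.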